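Swapping oxygen for selenium on an aspirin-derived carbonyl

The compounds below may be only part of what the source reports. "The series", "measured", "known", "first", "only" and "open" are said of these compounds alone.

Of the compounds shown here, three have been measured in a functional assay on PANC-1 cells (Homo sapiens) for antiproliferative activity, read by MTT assay, with a stated time of 72 h; on this read-out lower numbers stand for stronger inhibition and higher numbers for weaker inhibition. Compound 1 `CC(=O)Oc1ccccc1C(=O)NCC[Se]C#N` gives 2600 nM. Compound 2 `CC(=O)Oc1ccccc1C(=O)OCC[Se]C#N` gives 15100 nM, the highest number of the three, and compound 3 `CC(=O)Oc1ccccc1C(=O)[Se]CC[Se]C(=O)c1ccccc1OC(C)=O` gives 3400 nM. Compound 2 therefore stands furthest from strong inhibition among the measured set, with compound 3 nearer to it than compound 1.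

Compound 4 `CC(=O)Oc1ccccc1C(=O)[Se]CC[Se]C#N` is not yet measured. It arises from compound 2 by a group of 6 heavy atoms (3 carbon, 1 nitrogen, 2 selenium; no ring) in place of a group of 6 heavy atoms (3 carbon, 1 nitrogen, 1 oxygen, 1 selenium; no ring), on a carbonyl carbon. Among the measured compounds shown here, the only measured step at the same place is a 5.8-fold higher number from compound 1 to compound 2 (0.76 log units; beyond the scatter), which shows that a change on this carbonyl carbon can shift the read-out by a modest amount beyond the scatter. For the measured compounds named here, compound 3, which carries selenium on both of its carbonyl carbons, sits well below compound 2 on the numbers, while no step between the two is counted here.

On this basis a lower number is expected for compound 4 than for compound 2, with the size of the step estimated as a 3.8-fold lower number from compound 2 to compound 4 (0.58 log units; beyond the scatter). The estimate for compound 4 in this assay is 4000 nM, within a range from 1500 nM to 12000 nM.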

Compound 4, half-maximal inhibitory concentration: 9600 nM
Beside the measured number, compound 4's estimate is 2.4-fold (0.38 log units) below it, within the range that was stated.
By their numbers in this assay, from the lowest: compounds 1 and 3 (each within the scatter of the next); then compounds 4 and 2 (each within the scatter of the next).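

On this carbonyl carbon, putting selenium where compound 2 has oxygen gives a 1.6-fold lower number from compound 2 to compound 4 (0.20 log units; within the scatter) in this assay, so the two linking atoms cannot be told apart in this read-out. The nitrogen link of compound 1 now differs from both of them: the earlier comparison gave a 5.8-fold higher number from compound 1 to compound 2 (0.76 log units; beyond the scatter), and the new one gives a 3.7-fold higher number from compound 1 to compound 4 (0.57 log units; beyond the scatter), so the single gap seen before is not specific to oxygen but also appears with selenium. Nothing measured here offers an explanation for why the nitrogen link differs from the other two.

On these data alone, it remains open whether a sulfur atom or a methylene carbon on this carbonyl carbon would give a number like that of compound 1 or like those of compound 2 and compound 4. A longer chain in the same group, with the nitrile kept at its end, could also show whether the gap between the nitrogen link and the other two persists when the distance to the carbonyl changes.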